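Inverted Ring Stereochemistry of a Plasma-Assay Sulfonamide

The compounds below may be only part of what the source reports. "The series", "measured", "known", "first", "only" and "open" are said of these compounds alone.

Measured compounds:
- compound 1, `O=C(O)CCC/C=C\C[C@@H]1[C@H](O)CC[C@H]1NS(=O)(=O)c1ccc(F)cc1`: 6000 nM
- compound 2, `C[C@@H]1CC/C(=N\OC(c2ccccc2)c2ccccc2)[C@H]1C/C=C\CCCC(=O)O`: 800 nM
- compound 3, `O=C(O)CCC/C=C\C[C@H]1/C(=N/OCC2CCCCC2)CC[C@@H]1NS(=O)(=O)c1ccc(Cl)cc1`: 1700 nM

All three were tested in a functional assay (plasma) for inhibition, with Homo sapiens as the target; a higher number here means a weaker inhibitor, a lower number a stronger inhibitor. Compound 1 has the highest number of the three and is therefore the weakest inhibitor shown; compound 3 sits below it by a step beyond the scatter, and compound 2 lies furthest below, also beyond the scatter.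

Compound 4, `O=C(O)CCC/C=C\C[C@@H]1[C@@H](NS(=O)(=O)c2ccc(F)cc2)CC[C@@H]1O`, is not yet measured. It differs from compound 1 only in configuration: the two compounds have the same atoms and bonds and differ only in configuration as drawn: 3 of 4 stereo elements differ; a stereocentre at a saturated ring carbon is drawn S in compound 1 and R in compound 4; a stereocentre at a saturated ring carbon is drawn R in compound 1 and S in compound 4; a stereocentre at a saturated ring carbon is drawn R in compound 1 and S in compound 4. Within the data shown here, no measured pair here differs only in configuration, so nothing in these data shows how large such a change can be. In cases of this kind the effect may run either way, and often it is large. Without a guide, the step from compound 1 to compound 4 is expected to be modest and toward a weaker inhibitor, a 1.5-fold higher number from compound 1 to compound 4 (0.18 log units; within the scatter), but with a wide range. Compound 4 is thus estimated at 9000 nM, between 1500 nM and 40000 nM.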

Compound 4, half-maximal inhibitory concentration: 640 nM
Compound 4: the middle estimate sits 14-fold (1.15 log units) above what was measured; the measured number lies below the stated range.
By their numbers in this assay, from the lowest: compounds 4 and 2 (each within the scatter of the next); then compound 3; then compound 1.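

Among these compounds, compounds 1 and 4 form the first pair here with the same atoms and bonds, so configuration can be judged apart from any change of group. In this assay the pair shows a 9.4-fold lower number from compound 1 to compound 4 (0.97 log units; beyond the scatter), a step beyond the scatter, so the arrangement of the sulfonamide, the hydroxyl and the side chain on the shared core matters on its own at these ring carbons. The step can be assigned to configuration alone because of what separates the pair: the fact that compounds 1 and 4 differ only in the configuration as drawn.

From the compounds shown here alone, the pair moves all three ring stereocentres together, so which of them carries the step remains open. Also open, going by these compounds, is whether the configuration of compound 4 keeps its advantage when the hydroxyl gives way to an amine or a methoxy group.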